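The source may hold more compounds than are shown below. What is called first, only, known or untested is meant among the compounds shown, and "the series" means these compounds.

Measured compounds:
Compound 1 `CCNc1ccc(C(=O)N2CCCCc3cc(Cl)ccc32)c(Cl)c1` gives 5 nM in an assay on HeLa cells for binding affinity to Vasopressin V2 receptor (Homo sapiens); on this read-out higher numbers stand for weaker inhibition and lower numbers for stronger inhibition.
Compound 2 `CCCNc1ccc(C(=O)N2CCCCc3ccccc32)c(Cl)c1` gives 18 nM in this assay.
Compound 3 `O=C(c1ccc(N2CCCC2)cc1)N1CCCCc2cc(Cl)ccc21` gives 210 nM in this assay.

Compound 2 stands second highest among the three numbers. Its nearest neighbour is compound 1, whose value is lower by a margin beyond the scatter; its furthest is compound 3, whose value is higher, again beyond the scatter. Compound 4 `CC1CCN(c2ccc(C(=O)N3CCCCc4ccccc43)c(Cl)c2)C1` has not yet been measured. It differs from compound 2 in one place: 3-methylpyrrolidin-1-yl in place of propylamino on an aromatic carbon. The amine thus becomes part of a five-membered ring, and the donor that compound 2 carries at this position is lost, while the chloro group that compound 3 lacks on the shared core is kept.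

Going by the values given here, no step between measured compounds isolates this change, so the expectation rests on comparison alone. Compound 3, which also carries a cyclic amine at the same site but without the second chloro group, sits well above compound 2, and compound 1, an open-chain amine, sits below it. Compound 4 is expected to land somewhat above compound 2, a modest loss that may or may not clear the scatter. The estimated step of a 2.2-fold higher number from compound 2 to compound 4 (0.35 log units; beyond the scatter) reflects this. Compound 4 is therefore estimated at 40 nM, with a range from 10 nM to 150 nM.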

Compound 4, half-maximal inhibitory concentration: 51 nM
The estimate for compound 4 lay 1.3-fold (0.11 log units) below the measured number, and the stated range covers the measured number.
By their numbers in this assay, from the lowest: compound 1; then compound 2; then compound 4; then compound 3.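

In this assay, putting 3-methylpyrrolidin-1-yl in place of propylamino on this aromatic carbon, para to a large group and meta to a chloro group, gives a 2.8-fold higher number from compound 2 to compound 4 (0.45 log units; beyond the scatter), the only step shown that isolates a change at this site. The group that leaves has a hydrogen-bond donor and no ring, whereas the group that enters has a five-membered non-aromatic ring, no donor and more heavy atoms, yet the step is modest and compound 4 still gives 51 nM, so at this position neither the open chain nor the donor is indispensable for measurable binding. Nothing available explains the size of this step or assigns it to the lost donor, the ring or the methyl group.

Going by these compounds, what remains open is how much of the step belongs to each part of the change: an unsubstituted pyrrolidin-1-yl group on the same core would show the share of the methyl group, and an N-methylpropylamino group would remove the donor while keeping the open chain. A piperidin-1-yl group at the same carbon would show whether a six-membered ring fits this position as well as the five-membered ring of compound 4.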